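The source may report more compounds than this note shows. Statements on the series, on what has been measured and on what is new or still open speak of the compounds shown alone.

Working notes on the series. The shared core carries an amine whose substituent is varied; the read-out is a functional assay on MGC-803 cells (Homo sapiens) for inhibition, read by sulforhodamine B assay; on this read-out higher numbers stand for weaker inhibition and lower numbers for stronger inhibition.

Compound 1 `O=C1C(NC2CCCC2)=CC(=O)c2c1nc1n2[C@H]2OC[C@@H](O)[C@H]2OC1` carries cyclopentyl on the amine nitrogen. In this assay compound 1 reports only a limit, > 16000 nM; this is the limit named in the limit of > 16000 nM in this assay, at which 1 of the 3 values shown sits, so no number for compound 1 is known.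

Compound 2 `Cc1ccc(NC2=CC(=O)c3nc4n(c3C2=O)[C@H]2OC[C@@H](O)[C@H]2OC4)cc1` carries 4-methylphenyl on the same nitrogen and gives 1420 nM in this assay. Compound 3 `O=C1C=C(Nc2ccc(I)cc2)C(=O)c2c1nc1n2[C@H]2OC[C@@H](O)[C@H]2OC1` carries 4-iodophenyl and gives 1400 nM. Going by the values given here, the one measured step, a 1.0-fold lower number from compound 2 to compound 3 (0.01 log units; within the scatter), shows that exchanging the substituent on the aromatic carbon leaves the number essentially unchanged. Both aryl compounds sit well inside the measurable range, whereas compound 1 does not.

Compound 4 `CCCc1ccc(NC2=CC(=O)c3c(nc4n3[C@H]3OC[C@@H](O)[C@H]3OC4)C2=O)cc1` is to be measured. It differs from compound 1 by 4-propylphenyl in place of cyclopentyl on an amine nitrogen. Among the compounds with values here, no measured step covers the exchange of cyclopentyl for an aryl group; only the values of compounds 2 and 3 bear on it, and they place aryl amines far below the limit at which compound 1 stands. The step of a 1.0-fold lower number from compound 2 to compound 3 (0.01 log units; within the scatter) suggests that the particular substituent on the phenyl ring matters little, so 4-propylphenyl is expected to behave like the other aryl groups.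

Compound 4 is therefore expected near the aryl pair, 1500 nM, within 600 nM to 4000 nM. The expected step is an at least 10-fold lower number from compound 1 to compound 4 (1.02 log units; beyond the scatter), a move to a lower number and stronger inhibition, its size bounded only by the limit of compound 1.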

Compound 4, half-maximal inhibitory concentration: 1920 nM
Beside the measured number, compound 4's estimate is 1.3-fold (0.11 log units) below it; measured number inside the range.
By their numbers in this assay, from the lowest: compounds 3, 2 and 4 (each within the scatter of the next). At a limit, above all of these: compound 1.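

On the amine nitrogen of the shared core, this assay now gives a direct comparison in one place: 4-propylphenyl in place of cyclopentyl brings an at least 8.3-fold lower number from compound 1 to compound 4 (0.92 log units; beyond the scatter). Compound 1 stands at a limit, and the step is therefore a bound and not a measured size: the limit of > 16000 nM in this assay, at which 1 of the 4 values shown sits.

Compound 2 gives 1420 nM and compound 4 gives 1920 nM, which lie within the scatter of each other, so the propyl group on the phenyl ring does not separate from the methyl group at this read-out.

The compounds shown leave open whether the gap to compound 1 belongs to the aromatic ring itself or simply to the larger substituent, as cyclopentyl is the only non-aromatic group here, and a cyclohexyl or benzyl group on the amine nitrogen would tell these two readings apart. Also open, going by these compounds, is whether the phenyl ring tolerates a carboxylic acid or an amine as it does the methyl, iodo and propyl groups of compounds 2, 3 and 4.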